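Swapping the phenolic hydroxy for chloro on the enone

The source may hold more compounds than are shown below. What is called first, only, known or untested is meant among the compounds shown, and "the series" means these compounds.

For the measured compounds named here, compound 2 `O=C(/C=C/c1cc2ccccc2[nH]c1=O)c1ccc(O)cc1` is the one compound with a plain numeric result: in a functional assay on RPMI-8226 cells (Homo sapiens) for cytotoxicity, read by sulforhodamine B assay, with a stated time of 24 h (a higher number here means a weaker inhibitor of growth, a lower number a stronger inhibitor of growth), compound 2 gives 24800 nM. Its methyl ether counterpart is compound 1 `COc1ccc(C(=O)/C=C/c2cc3ccccc3[nH]c2=O)cc1`. For compound 1 the reading in this assay of > 100000 nM is a limit of the assay rather than a number (the limit of > 100000 nM in this assay, at which 1 of the 2 values shown sits). Going by the values given here, the single measured step, an at least 4.0-fold lower number from compound 1 to compound 2 (0.60 log units; beyond the scatter), shows that uncovering the hydroxy markedly strengthened growth inhibition.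

Compound 3 `O=C(/C=C/c1cc2ccccc2[nH]c1=O)c1ccc(Cl)cc1` differs from compound 2 by chloro in place of hydroxy on an aromatic carbon. The hydroxy that set compound 2 apart from compound 1 thus leaves again, and chloro, without a hydrogen-bond donor, takes its place. Among the compounds with values here, only the step of an at least 4.0-fold lower number from compound 1 to compound 2 (0.60 log units; beyond the scatter) bears on this change, and it points toward weaker growth inhibition in this assay once the hydroxy is removed. Compound 3 is therefore expected to show a 2.8-fold higher number from compound 2 to compound 3 (0.45 log units; beyond the scatter). Compound 3 is estimated at 70000 nM, within 20000 nM to 250000 nM, with a real chance that only a limit is recorded.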

Compound 3, concentration for total growth inhibition: 16100 nM
Beside the measured number, compound 3's estimate is 4.3-fold (0.64 log units) above it, and the stated range ends above it.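

With a 1.5-fold lower number from compound 2 to compound 3 (0.19 log units; within the scatter), the hydrogen-bond donor of the hydroxy proves not to be required at this place in this assay: chloro, which has 0 hydrogen-bond donors, leaves growth inhibition level with that of compound 2. The gain on leaving the methoxy group therefore does not depend on a free hydroxy, as an at least 6.2-fold lower number from compound 1 to compound 3 (0.79 log units; beyond the scatter) appears with chloro as well. The reading of compound 1 is a limit of the assay, and this step gives only a lower bound on the size of the change: the limit of > 100000 nM in this assay, at which 1 of the 3 values shown sits.

As far as these compounds go, how an amine, a carboxylic acid or a fluoro group at the same place would read in this assay stays open. The compounds shown also leave open whether a longer chain on the oxygen would read like the methoxy group of compound 1.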